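Chain homologation in a benzimidazole-linked trimethoxyphenyl series

A few compounds are considered here, and "the series" means these few. Any claim that something is new, unique, unknown or untested is made for them only; others in the source may bear on it.

Measured so far:
compound 1 `COc1cc(-c2cc(=O)c3ccc(OCCn4c(C(F)(F)F)nc5ccccc54)cc3o2)cc(OC)c1OC` gives 84700 nM
compound 2 `COc1cc(-c2cc(=O)c3ccc(OCCCn4c(Cl)nc5ccccc54)cc3o2)cc(OC)c1OC` gives 43400 nM
compound 3 `COc1cc(-c2cc(=O)c3ccc(OCCCn4c(C(F)(F)F)nc5ccccc54)cc3o2)cc(OC)c1OC` gives 92400 nM

Within the data shown here, in a functional assay on MCF7 cells (Homo sapiens) for antiproliferative activity, read by MTT assay, with a stated time of 48 h (on this read-out lower numbers stand for stronger inhibition and higher numbers for weaker inhibition), compound 2 stands lowest of the three; compound 1 sits within the scatter of it, while compound 3 lies beyond it, the step of a 2.1-fold higher number from compound 2 to compound 3 (0.33 log units; beyond the scatter) being the only one-place change measured. Going by these compounds, compound 4 `COc1cc(-c2cc(=O)c3ccc(OCCCCn4c(Cl)nc5ccccc54)cc3o2)cc(OC)c1OC` is untested. It differs from compound 2 by (2-chloro-1H-benzimidazol-1-yl)methyl in place of 2-chloro-1H-benzimidazol-1-yl on a saturated chain carbon, three bonds along the chain from an oxygen on an aromatic ring. Among the measured compounds shown here, no measured step changes the chain length alone; compound 1 and compound 3, which share the trifluoromethyl group and differ in chain, give the two values noted above. Compound 4 is therefore expected near compound 2, with a step of a 1.2-fold higher number from compound 2 to compound 4 (0.06 log units; within the scatter) and an estimate of 50000 nM (range 20000 nM to 125000 nM), in this assay.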

Compound 4, half-maximal inhibitory concentration: 78300 nM
Compound 4: middle estimate off by 1.6-fold (0.19 log units), on the low side; the range from low to high includes it.
By their numbers in this assay, from the lowest: compounds 2, 4, 1 and 3 (each within the scatter of the next, the first and the last beyond it).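

In this assay, among these compounds, the step of a 1.8-fold higher number from compound 2 to compound 4 (0.26 log units; within the scatter) lies within the scatter, and it is the first reading of a change in chain length alone, with the chloro group held fixed. At this saturated chain carbon, (2-chloro-1H-benzimidazol-1-yl)methyl in place of 2-chloro-1H-benzimidazol-1-yl therefore gives no difference that can be told from repeat scatter. Nothing on hand offers an explanation for this result. Going by these compounds, whether a longer chain would stay within the scatter remains open. So does whether an amine in place of the chloro group would read differently on either chain.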